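The compounds below may be only part of what the source reports. "The series", "measured", "known", "first", "only" and "open" are said of these compounds alone.

Working notes on the series. Compound 1 `COc1cccc(Oc2c(NS(=O)(=O)c3ccc(C(C)(C)C)cc3)ncnc2OCCO)c1` gives 160 nM in an assay on cells (Endothelial cell) for binding affinity to Endothelin-1 receptor (Sus scrofa); a lower number here means a stronger inhibitor, a higher number a weaker inhibitor. Compound 2 `COc1cccc(Oc2c(NS(=O)(=O)c3ccc(C(C)(C)C)cc3)ncnc2OCCOc2ccncn2)c1` gives 1.2 nM, and compound 3 `COc1cccc(Oc2c(NS(=O)(=O)c3ccc(C(C)(C)C)cc3)ncnc2OCCOc2ncc(Br)cn2)c1` gives 0.051 nM, the lowest number of the three measured: a 24-fold lower number from compound 2 to compound 3 (1.37 log units; beyond the scatter), a 3100-fold lower number from compound 1 to compound 3 (3.50 log units; beyond the scatter). Compound 4 `COc1cccc(Oc2c(NS(=O)(=O)c3ccc(C(C)(C)C)cc3)ncnc2SCCOc2ncccn2)c1` differs from compound 3 by (2-((pyrimidin-2-yl)oxy)ethyl)sulfanyl in place of 2-((5-bromopyrimidin-2-yl)oxy)ethoxy on an aromatic carbon. Within the data shown here, two parts of the earlier steps bear on this: the gain from the pyrimidinyl ether itself (a 130-fold lower number from compound 1 to compound 2 (2.12 log units; beyond the scatter)) and the difference between the two pyrimidinyl groups (a 24-fold lower number from compound 2 to compound 3 (1.37 log units; beyond the scatter)). Among the measured compounds shown here, no measured pair covers the change from oxygen to sulfur at the ring attachment. Compound 4 is expected to give a higher number than compound 3, roughly back toward compound 2, as a 12-fold higher number from compound 3 to compound 4 (1.07 log units; beyond the scatter); the estimate for compound 4 is 0.6 nM, with a range from 0.1 nM to 4 nM.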

Compound 4, half-maximal inhibitory concentration: 25.8 nM
For compound 4 the middle estimate is 43-fold (1.63 log units) below the measured one; the whole stated range lies below it.
By their numbers in this assay, from the lowest: compound 3; then compound 2; then compound 4; then compound 1.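

In this assay the (2-((pyrimidin-2-yl)oxy)ethyl)sulfanyl chain keeps only a modest part of the gain over the 2-hydroxyethoxy chain (a 6.2-fold lower number from compound 1 to compound 4 (0.79 log units; beyond the scatter)). It falls well short of both ether chains (a 22-fold higher number from compound 2 to compound 4 (1.33 log units; beyond the scatter); a 510-fold higher number from compound 3 to compound 4 (2.70 log units; beyond the scatter)), so this position does not tolerate this combined change. Nothing available here accounts for the loss.

As far as these compounds go, each step changes the attachment atom and the pyrimidinyl group together, so the share of the sulfur stays open. The 2-((pyrimidin-2-yl)oxy)ethoxy chain and the 2-((5-bromopyrimidin-2-yl)oxy)ethylsulfanyl chain would separate the two.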